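Swapping the ether chain for an all-carbon chain

A few compounds are considered here, and "the series" means these few. Any claim that something is new, unique, unknown or untested is made for them only; others in the source may bear on it.

Compound 1 `COC[C@H](C)[C@H](C)C(c1ccc(O)c(OC)c1)c1ccc(O)c(OC)c1` gives 82000 nM in a functional assay on HL-60 cells (Homo sapiens) for cytotoxicity, read by WST assay, with a stated time of 48 h (a higher number here means a weaker inhibitor, a lower number a stronger inhibitor), as measured
Compound 2 `COC[C@@H](C)[C@@H](C)C(c1ccc(O)c(OC)c1)c1ccc(O)c(OC)c1` gives 85000 nM in this assay as measured

Among the measured compounds shown here, compound 2 stands level with compound 1, the only other measured compound. For the measured compounds named here, the step is a 1.0-fold higher number from compound 1 to compound 2 (0.02 log units; within the scatter) and lies within the scatter, and the only difference within the pair is the fact that compounds 1 and 2 differ only in the configuration as drawn as the structures show.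

Compound 3 `COc1cc(C(c2ccc(O)c(OC)c2)[C@H](CC(C)C)C(C)C)ccc1O` brings a different kind of change, namely 1-isopropyl-3-methylbutyl in place of 2-(methoxymethyl)-1-methylpropyl on a saturated chain carbon bound to two aromatic carbons at the same place in the series. Going by the values given here, the one measured step concerns configuration alone, so it gives no direct measure of a chain exchange. A moderate move towards a lower number is expected, though on thin grounds. The estimated change is a 2.8-fold lower number from compound 2 to compound 3 (0.45 log units; beyond the scatter) in this assay with wide uncertainty. For compound 3 the estimate is 30000 nM with an expected range of 8000 nM to 90000 nM in this read-out.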

Compound 3, half-maximal inhibitory concentration: 9600 nM
The estimate for compound 3 lay 3.1-fold (0.49 log units) above the measured number; the measured number falls inside the stated range.
By their numbers in this assay, from the lowest: compound 3; then compounds 1 and 2 (each within the scatter of the next).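

On a saturated chain carbon bound to two aromatic carbons, 1-isopropyl-3-methylbutyl in place of 2-(methoxymethyl)-1-methylpropyl gives steps beyond the scatter in this assay: an 8.9-fold lower number from compound 2 to compound 3 (0.95 log units; beyond the scatter) and an 8.5-fold lower number from compound 1 to compound 3 (0.93 log units; beyond the scatter). This place therefore responds to an exchange of the chain, which the configuration change within the earlier pair did not show. The step reads much the same from either partner of that pair, and the two partners are related by one fact: the fact that compounds 1 and 2 differ only in the configuration as drawn.

The exchange alters several things at once, since the entering chain is all carbon, has no hydrogen-bond acceptor and has one defined stereocentre rather than two, so the compounds shown do not separate these changes. Also open, from the compounds shown here alone, are the effect of inverting the stereocentre of compound 3 and of placing an amine or a carboxylic acid on the chain.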